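This account rests on a few compounds, and the source may have more. Where it says the series, first, only, none or still open, it means among the compounds named here.

Measured in an ADME assay on HFF cells (Homo sapiens) for cytotoxicity, read by neutral red uptake; on this read-out lower numbers stand for higher toxicity in this test and higher numbers for lower toxicity in this test:
- compound 1 `Nc1nc2c(ncn2/C=C2\C[C@@H]2[C@H](O)CO)c(=O)[nH]1`: > 300000 nM (a limit, not a number)
- compound 2 `Nc1nc2c(ncn2/C=C2/C[C@H]2[C@@H](O)CO)c(=O)[nH]1`: 299000 nM

Among the compounds with values here, compound 2 holds the only actual number, as the other value shown is a limit.

The next compound is compound 3 `Nc1nc2c(ncn2/C=C2/C[C@@H]2[C@H](O)CO)c(=O)[nH]1`, which is related to compound 2 as follows: the two compounds have the same atoms and bonds and differ only in configuration as drawn: 2 of 3 stereo elements differ; a stereocentre at a saturated ring carbon is drawn R in compound 2 and S in compound 3; a stereocentre at a saturated chain carbon is drawn R in compound 2 and S in compound 3. No group leaves or enters.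

Within the data shown here, one measured step bears on this change: a number no higher from compound 1 to compound 2 (the limit leaves the size open). That step can be traced only to the fact that compounds 1 and 2 differ only in the configuration as drawn. Its size cannot be read because of the limit of > 300000 nM in this assay, at which 1 of the 2 values shown sits. It therefore gives a direction but no magnitude, and it rests on a single pair.

Among the measured compounds shown here, with that as the only guide to a change of configuration, no step beyond the scatter is expected in this assay. Compound 3 may also return only a limit.

The expected value for compound 3 is 280000 nM, with an estimated range from 130000 nM to 400000 nM. This estimate means an expected 1.1-fold lower number from compound 2 to compound 3 (0.03 log units; within the scatter).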

Compound 3, half-maximal cytotoxic concentration: > 300000 nM
Compound 3: no number, only a limit (the forecaster's own chance of this, stated with the estimate: 65%); middle value at least 1.0-fold (0.02 log units) away from the limit.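

In this assay compound 3 gives > 300000 nM, which is a limit and not a number. Compound 3 separates the two kinds of configurational change, as it shares the double bond as drawn with compound 2 and the two stereocentres as drawn with compound 1; changing only the ring and chain stereocentres gives a number no lower from compound 2 to compound 3 (the limit leaves the size open). The size of this step cannot be read, and neither can the size of the step that changes only the double bond, because two of the three compounds give only a limit: the limit of > 300000 nM in this assay, at which 2 of the 3 values shown sit.

Going by these compounds, whether either change of configuration alters this read-out by more than the usual scatter remains open, since every comparison here involves at least one limit. The compounds shown also leave open how this assay responds when the atoms themselves change, for example with an amine or a carboxylic acid in place of a hydroxyl group.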